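Swapping a difluorophenyl for an iodophenyl on a shared core

A few compounds are considered here, and "the series" means these few. Any claim that something is new, unique, unknown or untested is made for them only; others in the source may bear on it.

Compound 1 `COc1cc2c(Nc3cccc(Br)c3F)ncnc2c(OC)c1OC` — in a functional assay on SGC-7901 cells (Homo sapiens) for antiproliferative activity, read by MTT assay, with a stated time of 72 h (a lower number here means a stronger inhibitor, a higher number a weaker inhibitor), compound 1 gives > 30000 nM, a limit of the assay rather than a number.
Compound 2 `COc1cc2c(Nc3cccc(F)c3F)ncnc2c(OC)c1OC` — in this assay compound 2 gives > 30000 nM, again a limit rather than a number.

Compound 2 thus stands only at a limit, and the step that the two limits leave unreadable from compound 1 to compound 2 cannot be read because of the limit of > 30000 nM in this assay, at which 2 of the 2 values shown sit. Compound 3 `COc1cc2c(Nc3cccc(I)c3)ncnc2c(OC)c1OC` differs from compound 2 by 3-iodophenyl in place of 2,3-difluorophenyl on a nitrogen on an aromatic ring. Among the compounds with values here, no measured step bears on this change; the single step between compound 1 and compound 2 is unreadable. Compound 3 is expected to give 20000 nM, within 3000 nM to 60000 nM, an expected step of an at least 1.5-fold lower number from compound 2 to compound 3 (0.17 log units; that floor lies within the scatter) that remains uncertain.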

Compound 3, half-maximal inhibitory concentration: 8640 nM
Compound 3: the middle estimate sits 2.3-fold (0.36 log units) above what was measured; the measured number falls inside the stated range.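

In this assay, within the data shown here, 3-iodophenyl on the nitrogen gives the only value on the shared core that is a number rather than a limit, with an at least 3.4-fold lower number from compound 2 to compound 3 (0.54 log units; beyond the scatter) and an at least 3.4-fold lower number from compound 1 to compound 3 (0.54 log units; beyond the scatter). The group on this nitrogen can therefore change the read-out, which the two earlier compounds could not show. Both steps are floors rather than exact sizes: the limit of > 30000 nM in this assay, at which 2 of the 3 values shown sit.

Whether the iodine or the absence of fluorine accounts for the change stays open. So does how a phenyl carrying an amine or a carboxylic acid in place of iodine would fare.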